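The source may hold more compounds than are shown below. What is called first, only, known or untested is meant among the compounds shown, and "the series" means these compounds.

Measured so far in a functional assay on SK-OV-3 cells (Homo sapiens) for antiproliferative activity, read by MTT assay, with a stated time of 72 h; a lower number here means a stronger inhibitor, a higher number a weaker inhibitor:
- compound 1 `O=C(CCc1cccc2c1B(O)OC2)Nc1ccc(Cl)cc1`: 5000 nM
- compound 2 `O=C(CCc1cccc2c1B(O)OC2)Nc1cccc(-c2ccccc2)c1`: 250 nM
- compound 3 `O=C(CCc1cccc2c1B(O)OC2)Nc1cccc(-c2ccc(OC(F)(F)F)cc2)c1`: 560 nM

Among these three, compound 2 has the lowest number at 250 nM, ahead of compound 3 and well ahead of compound 1. Compound 2 is therefore the reference point for the next analogue, compound 4 `CSc1cccc(-c2cccc(NC(=O)CCc3cccc4c3B(O)OC4)c2)c1`.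

The change from compound 2 to compound 4 is methylsulfanyl in place of hydrogen on an aromatic carbon. Put simply, methylsulfanyl takes the place of hydrogen on an aromatic carbon, turning phenyl into 3-(methylsulfanyl)phenyl.

Among the compounds with values here, only one measured step bears on this change: a 2.2-fold higher number from compound 2 to compound 3 (0.35 log units; beyond the scatter), with trifluoromethoxy in place of hydrogen on an aromatic carbon. That step is modest and lies only just beyond the scatter. Within the data shown here, no measured compound carries methylsulfanyl, and a single substitution sets no pattern for this assay. No step beyond the scatter is therefore expected, though the range must stay wide on both sides.

The expected step is a 1.4-fold higher number from compound 2 to compound 4 (0.15 log units; within the scatter).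

For compound 4 the estimated value is 350 nM, with an expected range of 130 nM to 900 nM.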

Compound 4, half-maximal inhibitory concentration: 150 nM
Compound 4: the middle estimate sits 2.3-fold (0.37 log units) above what was measured; measured number inside the range.
By their numbers in this assay, from the lowest: compounds 4 and 2 (each within the scatter of the next); then compound 3; then compound 1.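

In this assay the phenyl of compound 2 tolerates methylsulfanyl on an aromatic carbon, meta to a large group (a 1.7-fold lower number from compound 2 to compound 4 (0.22 log units; within the scatter)), so adding these 2 heavy atoms leaves compound 4 within the scatter of compound 2. Until now the only substitution on this phenyl was trifluoromethoxy (a 2.2-fold higher number from compound 2 to compound 3 (0.35 log units; beyond the scatter)), a step beyond the scatter; compound 4 shows that a substituent on this ring need not bring a step of that kind, although the two groups also sit on different carbons, so this pair cannot separate the effect of the group from that of its place. No supporting data bear on why methylsulfanyl gives this result.

From the compounds shown here alone, it remains open whether methylsulfanyl would give the same outcome on the carbon that carries trifluoromethoxy in compound 3, and whether trifluoromethoxy would match compound 4 in the place methylsulfanyl occupies. Also open, going by these compounds, is how methoxy, an amine, a carboxylic acid or a longer chain such as ethylsulfanyl would read in that same place, since a single tolerated group does not define the limits of this position.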